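Methylsulfonyl to trifluoromethyl on the shared core

The compounds below may be only part of what the source reports. "The series", "measured", "known", "first", "only" and "open" are said of these compounds alone.

The series comprises compound 1 `C/C(=C\c1cc(-c2ccc(C#N)cc2)cs1)C(N)=O`, compound 2 `C/C(=C\c1cc(-c2ccc(S(C)(=O)=O)cc2)cs1)C(N)=O` and compound 3 `C/C(=C\c1cc(-c2ccc(C(F)(F)F)cc2)cs1)C(N)=O`, which differ only in the substituent on the six-membered aromatic ring of carbon only. In a functional assay on BGC-823 cells (Homo sapiens) for cytotoxicity, read by CCK-8 assay, with a stated time of 24 h (on this read-out lower numbers stand for stronger inhibition and higher numbers for weaker inhibition), compound 1 gives > 50000 nM, which is a limit of the assay rather than a number. In this assay compound 2 likewise gives > 50000 nM, again a limit. The step that the two limits leave unreadable from compound 1 to compound 2 therefore cannot be sized, since both ends sit at the limit of > 50000 nM in this assay, at which 2 of the 2 values shown sit. Compound 2 thus stands at the limit, with no number to place it among the others.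

The change to compound 3 is trifluoromethyl in place of methylsulfonyl on an aromatic carbon. Among the compounds with values here, no measured step bears on this exchange; the only step is unreadable. Nothing therefore points to a readable value in this assay, and the expected step that the limit leaves unreadable from compound 2 to compound 3 is placed near zero with wide uncertainty. Compound 3 is accordingly expected to give 60000 nM in this assay, between 15000 nM and 250000 nM, most likely reported again only as a limit.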

Compound 3, half-maximal inhibitory concentration: > 50000 nM
Compound 3: a limit, no number; the forecaster's own chance of this, stated with the estimate: 75%; the middle value is on the limit's open side.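

No step among compound 1, compound 2 and compound 3 can be read, as all three stand at a limit in this assay: the limit of > 50000 nM in this assay, at which 3 of the 3 values shown sit.

The compounds shown leave open how nitrile, methylsulfonyl and trifluoromethyl rank on the shared core, and whether any substituent there gives a readable value in this assay.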